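Swapping a Hydroxyphenyl for a Methoxyphenyl: Expected Inhibition

The source may report more compounds than this note shows. Statements on the series, on what has been measured and on what is new or still open speak of the compounds shown alone.

Compound 1 `Cc1cccc2c1N(CC(=O)O)C/C(=C\c1ccccc1)C2=O` gives 27.9%.
Compound 2 `Cc1ccc2c(c1)C(=O)/C(=C/c1ccccc1)CN2CC(=O)O` gives 4.23%.
Compound 3 `Cc1cccc2c1N(CC(=O)O)C/C(=C\c1cccc(O)c1)C2=O` gives 75.6%.

All three were tested in an assay on HL-60 cells for inhibition of glutathione S-transferase P (Homo sapiens), read by spectrophotometry, tested at 20 uM; on this read-out higher numbers stand for more inhibition at the one concentration tested (going by the name of the read-out) and lower numbers for less inhibition. Compound 3 stands highest of the three numbers; compound 1 is the nearest to it, and compound 2 lies furthest below. Compound 1 and compound 3 share the same core and differ in one place only, and the step between them was a number 47.7 percentage points higher from compound 1 to compound 3 (beyond the scatter), a change of hydroxy in place of hydrogen on an aromatic carbon. Compound 2 has a differently arranged core and its value is simply the lowest of the three.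

Compound 4 `COc1ccccc1/C=C1\CN(CC(=O)O)c2c(C)cccc2C1=O` has not yet been measured. It differs from compound 3 as follows: 2-methoxyphenyl in place of 3-hydroxyphenyl on a double-bonded chain carbon bound to a double-bonded ring carbon. Within the data shown here, the only measured step that bears on this change is the one from compound 1 to compound 3, which was large and shows that the hydroxy went with a strong rise. Among the measured compounds shown here, compound 4 gives that hydroxy up; what comes in is a 2-methoxyphenyl, and no measured pair shows what a methoxy does. A sizeable fall is therefore expected, back toward the level of compound 1, with wide uncertainty.

For compound 4 the value expected in this assay is 35%, within a range from 10% to 65%. This amounts to an expected step of a number 40.6 percentage points lower from compound 3 to compound 4 (beyond the scatter).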

Compound 4, a percentage reported as inhibition, at one concentration (the size of the read-out at that concentration, not a potency): 4.72%
For compound 4 the middle estimate is 30.3 percentage points above the measured one, outside the stated range (below it).
By their numbers in this assay, from the lowest: compounds 2 and 4 (each within the scatter of the next); then compound 1; then compound 3.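

In this assay, the step that adds a methoxy to the phenyl ring is a number 23.2 percentage points lower from compound 1 to compound 4 (beyond the scatter), so adding a group to this phenyl ring does not by itself go with more inhibition, and here it goes with less. The step from the 3-hydroxyphenyl to the 2-methoxyphenyl is a number 70.9 percentage points lower from compound 3 to compound 4 (beyond the scatter), which takes the number past the level of the unsubstituted phenyl rather than back to it, so the gain seen with compound 3 belongs to the 3-hydroxyphenyl and is not shared by this other oxygen-bearing ring. No measurement here explains why these groups differ so much at this position.

This swap changes two things at once, the group on the ring and where it sits, and the compounds shown cannot separate them: that would take a methoxy at the place the hydroxy holds in 3-hydroxyphenyl, or a hydroxy at the place the methoxy holds in 2-methoxyphenyl. On these data alone, it also remains open whether the rise depends on the hydroxy itself, or whether an amine or a carboxylic acid at that same place on the ring would go with a similar number.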